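The source may report more compounds than this note shows. Statements on the series, on what has been measured and on what is new or still open speak of the compounds shown alone.

Compound 1 `CCNC(=O)c1c(CNCc2ccc(OC)cc2)c2ccccc2n1Cc1ccc(OC)cc1` gives 58900 nM.
Compound 2 `COc1ccc(Cn2c(C(=O)O)c(CNCc3cc(OC)ccc3O)c3ccc(C)cc32)cc1` gives > 50000 nM.

In a functional assay on Bel-7402 cells (Homo sapiens) for antiproliferative activity, read by MTT assay, with a stated time of 72 h (on this read-out lower numbers stand for stronger inhibition and higher numbers for weaker inhibition), compound 1 gives 58900 nM. For compound 2 the value > 50000 nM is a limit of the assay, not a number, so compound 2 stands at the limit of > 50000 nM in this assay, at which 1 of the 2 values shown sits. Among the measured compounds shown here, no step between two measured compounds is available. Compound 3 `COc1ccc(Cn2c(C(=O)O)c(CNCc3cccc(OC)c3)c3ccc(C)cc32)cc1` differs from compound 2 by hydrogen in place of hydroxy on an aromatic carbon. Loss of a hydroxy gives no ground for expecting a change beyond the usual scatter, so the step from compound 2 to compound 3 is estimated at a step that the limit leaves unreadable from compound 2 to compound 3. Compound 3 is therefore expected to give 60000 nM in this assay, between 20000 nM and 200000 nM, most likely once more as a limit.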

Compound 3, half-maximal inhibitory concentration: 9830 nM
Compound 3: middle estimate off by 6.1-fold (0.79 log units), on the high side; measured number below the stated range.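

In this assay, replacing the 2-hydroxy-5-methoxybenzyl group with 3-methoxybenzyl gives an at least 5.0-fold lower number from compound 2 to compound 3 (0.70 log units; beyond the scatter), so a hydroxy ortho to a large group and para to a methoxy group is not neutral in this series. Compound 3, without that hydroxy, gives a readable number. Compound 2 stands at a limit of the assay, not a number, so the step reads only as a minimum: the limit of > 50000 nM in this assay, at which 1 of the 3 values shown sits.

The compounds shown leave open how a fluorine or an amine at this place would read. They also leave open whether the same change would count on the ethyl amide of compound 1.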